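Swapping the Ring-Nitrogen Aryl Group on Compound 3

This account rests on a few compounds, and the source may have more. Where it says the series, first, only, none or still open, it means among the compounds named here.

Compound 3 `CCNC(=O)c1cc(Oc2ccc(NC(=O)c3cc4cccnc4n(-c4ccccc4F)c3=O)cc2)ccn1` gives 260 nM in a functional assay on HT-29 cells (Homo sapiens) for antiproliferative activity, read by MTT assay, with a stated time of 72 h; a higher number here means a weaker inhibitor, a lower number a stronger inhibitor. Going by the values given here, compound 1 `CNC(=O)c1cc(Oc2ccc(NC(=O)c3cc4cccnc4n(-c4ccccc4F)c3=O)cc2)ccn1` gives 260 nM in this assay, and no change at the digits printed from compound 1 to compound 3 (within the scatter), so the two stand level and share the lowest number of the three measured so far. Compound 2 `CNC(=O)c1cc(Oc2ccc(NC(=O)c3cc4cccnc4n(-c4ccc(Br)cc4)c3=O)cc2)ccn1` gives 1180 nM in this assay, and a 4.5-fold higher number from compound 1 to compound 2 (0.66 log units; beyond the scatter), which sets compound 2 apart from both of the others.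

Compound 4 `CCNC(=O)c1cc(Oc2ccc(NC(=O)c3cc4cccnc4n(-c4ccc(Br)cc4)c3=O)cc2)ccn1` has not yet been measured. Its difference from compound 3 is this: 4-bromophenyl in place of 2-fluorophenyl on an aromatic nitrogen. Exactly this swap has already been seen once, on the shared core of compound 1: a 4.5-fold higher number from compound 1 to compound 2 (0.66 log units; beyond the scatter). The only other difference between that pair and the pair of compound 3 and compound 4 is the methyl added to the amide chain, and that addition showed no effect on its own, as no change at the digits printed from compound 1 to compound 3 (within the scatter). The expectation is therefore that compound 4 repeats the earlier loss in this assay, with a modest step that lies beyond the scatter.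

Compound 4 is thus expected to give 1200 nM in this assay, with a likely range from 500 nM to 3000 nM, which would mean an expected step of a 4.6-fold higher number from compound 3 to compound 4 (0.66 log units; beyond the scatter).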

Compound 4, half-maximal inhibitory concentration: 1160 nM
Compound 4: the middle estimate sits 1.0-fold (0.01 log units) above what was measured; measured number inside the range.
By their numbers in this assay, from the lowest: compounds 1 and 3 (each within the scatter of the next); then compounds 4 and 2 (each within the scatter of the next).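

In this assay, the swap on the aromatic nitrogen gives a 4.5-fold higher number from compound 3 to compound 4 (0.65 log units; beyond the scatter), so the loss first seen on the core of compound 1 now appears on a second core, at matching size: the same change on two cores in this assay, a 4.5-fold higher number (0.66 log units; beyond the scatter) from compound 1 to compound 2 and a 4.5-fold higher number (0.65 log units; beyond the scatter) from compound 3 to compound 4, 1.0-fold (0.01 log units) apart, within the scatter of two such steps. The methyl added to the saturated chain on the amide-type nitrogen is also now seen with 4-bromophenyl as well as 2-fluorophenyl, and it gives a 1.0-fold lower number from compound 2 to compound 4 (0.01 log units; within the scatter), again matching the earlier step: the same change on two cores in this assay, no change at the digits printed (within the scatter) from compound 1 to compound 3 and a 1.0-fold lower number (0.01 log units; within the scatter) from compound 2 to compound 4, 1.0-fold (0.01 log units) apart, within the scatter of two such steps. Across these four compounds, the group on the aromatic nitrogen separates the numbers into two pairs while the amide chain does not, and no compound shown goes against this.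

The swap changes both the halogen and where it sits on the phenyl ring, so these compounds cannot tell which of the two goes with the higher number; 4-fluorophenyl and 2-bromophenyl would pull them apart. How far the amide chain can grow also remains open, since a propyl chain or a chain ending in an amine could behave differently from the methyl and ethyl amides shown here.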